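This account rests on a few compounds, and the source may have more. Where it says the series, first, only, none or still open, it means among the compounds named here.

Working notes on the series in a physicochemical assay for solubility, read by HPLC, measured as kinetic solubility, with a stated time of 24 h, at pH 6.5; on this read-out higher numbers stand for higher solubility and lower numbers for lower solubility. Compound 2 `CCNCc1cc(C)cc(Nc2nc3ccccc3n2Cc2ccc(C(F)(F)F)cc2)c1O` gives 35000 nM and stands highest of the two numbers reported; compound 3 `CCNCc1cc(Cl)cc(Nc2nc3ccccc3n2Cc2ccc(C(F)(F)F)cc2)c1O` gives 12000 nM, and the step of a 2.9-fold lower number from compound 2 to compound 3 (0.46 log units; beyond the scatter) follows chloro in place of methyl on an aromatic carbon. Compound 1 `Cc1cc(CNC(C)(C)C)c(O)c(Nc2nc3cc(F)c(F)cc3n2Cc2ccc(C(F)(F)F)cc2)c1` returns only a limit, < 5000 nM, which is the limit of < 5000 nM in this assay, at which 1 of the 3 values shown sits, and not a number. Compound 4 `Cc1cc(CNC(C)(C)C)c(O)c(Nc2nc3ccccc3n2Cc2ccc(C(F)(F)F)cc2)c1` differs from compound 2 by tert-butyl in place of ethyl on an amine nitrogen. Among the compounds with values here, no measured step covers this change; compound 1 carries the same ((tert-butyl)amino)methyl group but also differs elsewhere, so its limit is only a hint. A modest decrease is expected, a 2.3-fold lower number from compound 2 to compound 4 (0.37 log units; beyond the scatter), with compound 4 estimated at 15000 nM, between 5000 nM and 40000 nM.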

Compound 4, solubility: 50000 nM
For compound 4 the middle estimate is 3.3-fold (0.52 log units) below the measured one; the measured number lies above the stated range.
By their numbers in this assay, from the lowest: compound 3; then compounds 2 and 4 (each within the scatter of the next). At a limit, below all of these: compound 1.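

On an amine nitrogen whose other neighbour is a saturated chain carbon, tert-butyl in place of ethyl gives the first step read at this position in this assay, and it stays within the scatter: a 1.4-fold higher number from compound 2 to compound 4 (0.15 log units; within the scatter). This single pair shows no separation between the two groups. Compound 1 carries the same ((tert-butyl)amino)methyl group but gives a limit and not a number: the limit of < 5000 nM in this assay, at which 1 of the 4 values shown sits.

Still open, as far as these compounds go, is whether a longer chain or a carboxylic acid on this nitrogen would give a step beyond the scatter. From the compounds shown here alone, whether the result holds on another core also remains open.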